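Replacing the Biaryl Arm of a Sulfonamide with Trifluoromethyl

A few compounds are considered here, and "the series" means these few. Any claim that something is new, unique, unknown or untested is made for them only; others in the source may bear on it.

Measured compounds:
compound 1, `Cc1ccc(-c2cccc(S(=O)(=O)N3CCC(N4CCC(C)CC4)CC3)c2)cc1`: 11 nM
compound 3, `CC1CCN(C2CCN(S(=O)(=O)c3cnc(Cl)s3)CC2)CC1`: 1800 nM
compound 2, `CC1CCN(C2CCN(S(=O)(=O)c3sc(Cl)nc3C3CC3)CC2)CC1`: > 5000 nM

All three were tested in a functional assay on DLD-1 cells (Homo sapiens) for antiproliferative activity, read by CellTiter-Glo, with a stated time of 72 h; a lower number here means a stronger inhibitor, a higher number a weaker inhibitor. Compound 1 stands lowest of the two numbers shown; its nearest neighbour is compound 3 at 1800 nM, far above it. For compound 2 the result is only a limit of the assay, not a number, as recorded in the limit of > 5000 nM in this assay, at which 1 of the 3 values shown sits.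

One step between measured compounds is available: an at least 2.7-fold lower number from compound 2 to compound 3 (0.44 log units; beyond the scatter). It concerns the ring that carries the sulfonyl group in compounds 2 and 3, not the change studied here, so it offers no direct guide.

Compound 4 is `CC1CCN(C2CCN(S(=O)(=O)c3cccc(C(F)(F)F)c3)CC2)CC1`. Relative to compound 1 the change is trifluoromethyl in place of 4-methylphenyl on an aromatic carbon. A whole aromatic ring leaves and a far smaller group enters on the shared core of compound 1, and a large rise in the number is expected, a 36-fold higher number from compound 1 to compound 4 (1.56 log units; beyond the scatter). Compound 4 is therefore estimated at 400 nM, with a range from 60 nM to 3000 nM.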

Compound 4, half-maximal inhibitory concentration: > 5000 nM
Compound 4 ended at the assay's limit (the forecaster's own chance of this, stated with the estimate: 15%); at least 12-fold (1.09 log units) between middle value and limit.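

Compound 4 gives no number, only a limit of the assay: the limit of > 5000 nM in this assay, at which 2 of the 4 values shown sit.

In this assay, putting trifluoromethyl in place of 4-methylphenyl on this aromatic carbon gives an at least 450-fold higher number from compound 1 to compound 4 (2.65 log units; beyond the scatter), a large step and the first one shown at this place on the core of compound 1. Within the data shown here, the earlier step concerned only compounds 2 and 3, so this is the first direct sign that the group on this carbon matters greatly for the number in this assay, and that trifluoromethyl does not stand in for 4-methylphenyl here.

Going by these compounds, what remains open is how much of 4-methylphenyl is needed, and whether its methyl or the ring itself counts for more. A plain phenyl, a pyridine ring or a methoxy group on this carbon would help to separate these possibilities.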